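The Same Ring Swap Carried to a Second Core

The source may hold more compounds than are shown below. What is called first, only, known or untested is meant among the compounds shown, and "the series" means these compounds.

Compound 1 `Cn1cnc(C(=O)NNC(=O)COc2ccc(C(=O)c3ccccc3)cc2)c1` and compound 3 `O=C(COc1ccc(C(=O)c2ccccc2)cc1)NNC(=O)c1ccc(=O)oc1` share one core and differ only by a group of 7 heavy atoms (5 carbon, 2 oxygen; one six-membered aromatic ring with 1 hetero atom) in place of a group of 6 heavy atoms (4 carbon, 2 nitrogen; one five-membered aromatic ring with 2 hetero atoms), on a carbonyl carbon. In an ADME assay on NIH3T3 cells (Mus musculus) for cytotoxicity, read by LDH release, with a stated time of 48 h (on this read-out lower numbers stand for stronger inhibition and higher numbers for weaker inhibition), compound 1 gives 97400 nM and compound 3 gives 88200 nM, which is a 1.1-fold lower number from compound 1 to compound 3 (0.04 log units; within the scatter). Compound 2 `Cn1cnc(C(=O)NNC(=O)COc2c(F)cc(C(=O)c3ccc(Cl)cc3)cc2Cl)c1` is built on a different core; the difference between the two cores is not broken down here. In this assay compound 2 gives 89300 nM, a number that sits within the scatter of both compound 1 and compound 3. Compound 4 `O=C(COc1c(F)cc(C(=O)c2ccc(Cl)cc2)cc1Cl)NNC(=O)c1ccc(=O)oc1` has not been measured; it stands to compound 2 exactly as compound 3 stands to compound 1, by a group of 7 heavy atoms (5 carbon, 2 oxygen; one six-membered aromatic ring with 1 hetero atom) in place of a group of 6 heavy atoms (4 carbon, 2 nitrogen; one five-membered aromatic ring with 2 hetero atoms), on a carbonyl carbon, at the same place. Because the earlier step of a 1.1-fold lower number from compound 1 to compound 3 (0.04 log units; within the scatter) stayed within the scatter, the step from compound 2 to compound 4 is expected to be a 1.1-fold lower number from compound 2 to compound 4 (0.04 log units; within the scatter). Compound 4 is therefore estimated at 82000 nM, with a likely range from 45000 nM to 150000 nM.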

Compound 4, half-maximal inhibitory concentration: 78600 nM
Compound 4: middle estimate off by 1.0-fold (0.02 log units), on the high side; the range from low to high includes it.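

In this assay replacing the 1-methyl-1H-imidazol-4-yl group with the six-membered ring gives a 1.1-fold lower number from compound 2 to compound 4 (0.06 log units; within the scatter) on the second core, and this small step matches the one on the first core: the same change on two cores in this assay, a 1.1-fold lower number (0.04 log units; within the scatter) from compound 1 to compound 3 and a 1.1-fold lower number (0.06 log units; within the scatter) from compound 2 to compound 4, 1.0-fold (0.01 log units) apart, within the scatter of two such steps. On these two cores, then, the change carries over in the plain sense that it leaves the number within the scatter both times. This does not show that the change has a real effect on the read-out, and two cores cannot show how it would behave on a third.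

From the compounds shown here alone, whether the same holds for other groups on that carbonyl carbon, such as a plain phenyl ring or a carboxylic acid, stays open. So does whether the two cores would still match in a different assay.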